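The source may hold more compounds than are shown below. What is called first, only, known or untested is meant among the compounds shown, and "the series" means these compounds.

In an ADME assay on MDCK cells (Canis lupus familiaris) for cytotoxicity, read by MTT assay, with a stated time of 24 h (on this read-out higher numbers stand for lower toxicity in this test and lower numbers for higher toxicity in this test), the three measured compounds share one core and differ in the aryl group on the sulfonyl sulfur. Compound 1 `N#CCCN(Cc1cccs1)S(=O)(=O)c1ccccc1F` gives > 205000 nM as a limit. Compound 2 `N#CCCN(Cc1cccs1)S(=O)(=O)c1cccc(F)c1` gives > 205000 nM as a limit too. Compound 3 `N#CCCN(Cc1cccs1)S(=O)(=O)c1ccc(Cl)cc1` likewise stands only at a limit of > 195000 nM and has no exact number. Compound 4 `N#CCCN(Cc1cccs1)S(=O)(=O)c1ccc(Br)cc1` carries bromo in place of chloro on an aromatic carbon of compound 3. The nearest evidence is a step that the two limits leave unreadable from compound 1 to compound 3 and a step that the two limits leave unreadable from compound 2 to compound 3 with no size to carry over. What is expected in this assay is an at least 1.1-fold lower number from compound 3 to compound 4 (0.05 log units; that floor lies within the scatter) and no change beyond the scatter in either direction. Compound 4 is estimated at 173000 nM within a range of 110000 nM to 230000 nM and is expected to be reported as a limit again.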

Compound 4, half-maximal cytotoxic concentration: > 173000 nM
Compound 4 ended at the assay's limit; the forecaster's own chance of this, stated with the estimate: 85%; the middle value sits exactly at the limit.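

Compound 4, like compound 1, compound 2 and compound 3, stands only at a limit, so none of its steps to those three can be read. The compounds shown leave open at what concentration any of the four reaches its half-maximal cytotoxic effect.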